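Moving the methoxy group of compound 3

The source may report more compounds than this note shows. Statements on the series, on what has been measured and on what is new or still open speak of the compounds shown alone.

Among the measured compounds shown here, in a functional assay on MCF7 cells (Homo sapiens) for antiproliferative activity, read by MTT assay, with a stated time of 48 h (a lower number here means a stronger inhibitor, a higher number a weaker inhibitor), compound 3 `COc1ccccc1N1CCN(C(=O)/C=C/c2ccc(O)c(O)c2)CC1` gives 0.54 ug/mL, the lowest of the three numbers so far. Compound 1 `O=C(/C=C/c1ccc(O)c(O)c1)N1CCN(c2ccccc2F)CC1` gives 1.38 ug/mL, and compound 2 `O=C(/C=C/c1ccc(O)c(O)c1)N1CCN(c2cccc(Cl)c2)CC1` gives 1.34 ug/mL.

Compound 4 `COc1ccc(N2CCN(C(=O)/C=C/c3ccc(O)c(O)c3)CC2)cc1` has not yet been measured. It has the same atoms as compound 3, joined differently, with 4-methoxyphenyl in place of 2-methoxyphenyl on an amine nitrogen in a ring.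

Three measured steps change the group at this place. One, a 1.0-fold lower number from compound 1 to compound 2 (0.01 log units; within the scatter), stays within the scatter, while a 2.6-fold lower number from compound 1 to compound 3 (0.41 log units; beyond the scatter) and a 2.5-fold lower number from compound 2 to compound 3 (0.39 log units; beyond the scatter) are modest. None of them moves a methoxy group, so the data offer only an indirect guide. Since all these steps are small, a large change is not expected in this assay. Any change is more likely to raise the number, given the low 0.54 ug/mL of compound 3. The expected change is small, a 1.6-fold higher number from compound 3 to compound 4 (0.20 log units; within the scatter). For compound 4, the estimated value is 0.85 ug/mL, with an expected range of 0.35 ug/mL to 2 ug/mL.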

Compound 4, half-maximal inhibitory concentration: 0.52 ug/mL
Compound 4: middle estimate off by 1.6-fold (0.21 log units), on the high side; measured number inside the range.
By their numbers in this assay, from the lowest: compounds 4 and 3 (each within the scatter of the next); then compounds 2 and 1 (each within the scatter of the next).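

In this assay, 4-methoxyphenyl in place of 2-methoxyphenyl gives a 1.0-fold lower number from compound 3 to compound 4 (0.02 log units; within the scatter), so the compounds shown do not separate these two methoxy-bearing groups at this place. Among the compounds shown here, the lower numbers relative to the fluoro and chloro compounds therefore do not belong to 2-methoxyphenyl alone: the new compound shows a 2.6-fold lower number from compound 2 to compound 4 (0.41 log units; beyond the scatter) and a 2.7-fold lower number from compound 1 to compound 4 (0.42 log units; beyond the scatter), much the same size as the earlier steps to compound 3. Nothing available accounts for why the two methoxy-bearing compounds give such similar numbers. Still open, as far as these compounds go, is whether the methoxy group itself matters, or whether an ethoxy group, a hydroxy group or a dimethylamino group in its place would give a similar number. A phenyl group with no added group at this place would give a further point of comparison for all four compounds.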